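From pentyloxy to ethylamino on a carbonyl carbon

This account rests on a few compounds, and the source may have more. Where it says the series, first, only, none or still open, it means among the compounds named here.

Compound 1 `CCCOC(=O)c1ccc(S(N)(=O)=O)cc1` gives 1.75
Compound 2 `CCCCCOC(=O)c1ccc(S(N)(=O)=O)cc1` gives 2.71

Both values come from a physicochemical assay for lipophilicity; a higher number here means a more lipophilic compound, a lower number a more polar compound. Of the two measured compounds, compound 2 stands highest at 2.71 in this assay. Among the compounds with values here, the only measured step is a number 0.96 log units higher from compound 1 to compound 2 (beyond the scatter) and it comes from a change in the saturated chain alone.

Compound 3 `CCNC(=O)c1ccc(S(N)(=O)=O)cc1` has not yet been measured. On the way to it, ethylamino stands in place of pentyloxy on a carbonyl carbon (ethylamino in place of pentyloxy on a carbonyl carbon). The measured step bears on this change only in part, since ethylamino also carries a saturated chain and that chain is shorter than pentyloxy. Reading a number 0.96 log units higher from compound 1 to compound 2 (beyond the scatter) in reverse suggests a fall of at least that size. Within the data shown here, no measured step covers the replacement of the oxygen by the nitrogen with its hydrogen, so that share of the change remains an expectation without data, and the range is kept wide. Among the measured compounds shown here, a fall larger than the one measured step is expected, and the estimated change is a number 2.31 log units lower from compound 2 to compound 3 (beyond the scatter) in this assay. Compound 3 is estimated at 0.4 with an expected range from -0.2 to 0.9.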

Compound 3, partition coefficient: 0.03
For compound 3 the middle estimate is 0.37 log units above the measured one, within the range that was stated.
By their numbers in this assay, from the lowest: compound 3; then compound 1; then compound 2.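

In this assay, the carbonyl carbon now appears as a place where the outcome depends on more than the length of a saturated chain: ethylamino in place of pentyloxy gives a number 2.68 log units lower from compound 2 to compound 3 (beyond the scatter), and ethylamino in place of the shorter propoxy still gives a number 1.72 log units lower from compound 1 to compound 3 (beyond the scatter). Both of these steps are large, whereas the earlier step within the chain alone was modest, so exchanging either oxygen-linked chain for ethylamino places compound 3 lowest of the three. No independent finding accompanies these numbers, so the size of the change remains without an explanation here.

The compounds shown leave open how much of each step belongs to the nitrogen with its hydrogen and how much to the shorter chain, since ethylamino differs from both propoxy and pentyloxy in the linking atom and in the chain. A propylamino or pentylamino group on the same carbonyl carbon would separate those two shares, while a dimethylamino group would show what remains of the change without the hydrogen on nitrogen.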